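Bromo to Trifluoromethyl: Predicting Compound 4

The source may report more compounds than this note shows. Statements on the series, on what has been measured and on what is new or still open speak of the compounds shown alone.

Compound 1 `NC(=O)c1c(NC(=O)c2ccccc2Br)sc2c1CCN(C(=S)Nc1ccccc1Br)C2`, compound 2 `NC(=O)c1c(NC(=O)c2ccccc2Br)sc2c1CCN(C(=S)Nc1ccccc1C(F)(F)F)C2` and compound 3 `Cc1ccccc1NC(=S)N1CCc2c(sc(NC(=O)c3ccccc3Br)c2C(N)=O)C1` share one core and were tested in a functional assay on MKN-74 cells (Homo sapiens) for antiproliferative activity, with a stated time of 24 h; a higher number here means a weaker inhibitor, a lower number a stronger inhibitor. Compound 1 gives 13700 nM and compound 2 gives 24300 nM. For compound 3 the assay reports only a limit, > 50000 nM, so its position can only be bounded from one side (the limit of > 50000 nM in this assay, at which 1 of the 3 values shown sits). Compound 4 `Cc1ccccc1NC(=S)N1CCc2c(sc(NC(=O)c3ccccc3C(F)(F)F)c2C(N)=O)C1` differs from compound 3 in a single place: trifluoromethyl in place of bromo on an aromatic carbon. The same exchange, made elsewhere on the shared core, appears as a 1.8-fold higher number from compound 1 to compound 2 (0.25 log units; within the scatter). Among the compounds with values here, that is the only measured guide for this change. The step that the limit leaves unreadable from compound 3 to compound 4 is therefore expected to stay within the scatter. Compound 4 is estimated at 70000 nM, between 30000 nM and 200000 nM, most likely again reported only as a limit.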

Compound 4, half-maximal inhibitory concentration: 47400 nM
For compound 4 the middle estimate is 1.5-fold (0.17 log units) above the measured one; the range from low to high includes it.
By their numbers in this assay, from the lowest: compounds 1, 2 and 4 (each within the scatter of the next, the first and the last beyond it). At a limit, above all of these: compound 3.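

In this assay, trifluoromethyl on this aromatic carbon, ortho to a large group, gives a readable number on a core where bromo does not, with a step of an at least 1.0-fold lower number from compound 3 to compound 4 (0.02 log units; that floor lies within the scatter). For compound 3 the value > 50000 nM is a limit. The exchange can therefore be compared across the two cores only loosely: the same change on two cores in this assay, a 1.8-fold higher number (0.25 log units; within the scatter) from compound 1 to compound 2 and an at least 1.0-fold lower number (0.02 log units; that floor lies within the scatter) from compound 3 to compound 4; the limit leaves it open whether they differ

Going by these compounds, how large the true step is remains open, since it could be small or sizeable. Also open, on these data alone, is how an amine or a carboxylic acid would fare at this position on either core.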